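The source may report more compounds than this note shows. Statements on the series, on what has been measured and on what is new or still open speak of the compounds shown alone.

Measured compounds:
- compound 1, `CC(Nc1ccccc1Oc1ccc(Cl)cc1)=C1C(=O)CC(c2ccccc2)CC1=O`: 250 nM
- compound 2, `CC(=O)c1ccc(Oc2ccccc2NC(C)=C2C(=O)CC(c3ccccc3)CC2=O)cc1`: 190 nM
- compound 3, `CC(Nc1ccccc1Oc1cccc(N)c1)=C1C(=O)CC(c2ccccc2)CC1=O`: 53 nM

All three were tested in a functional assay on L1210 cells (Mus musculus) for antiproliferative activity, read by cell counting, with a stated time of 96 h; on this read-out lower numbers stand for stronger inhibition and higher numbers for weaker inhibition. Among them, compound 1 gives the highest number, 250 nM, and so the weakest inhibition. Compound 2 sits close to it, the step of a 1.3-fold lower number from compound 1 to compound 2 (0.12 log units; within the scatter) being a small one, whereas compound 3 lies clearly lower, through a 4.7-fold lower number from compound 1 to compound 3 (0.67 log units; beyond the scatter).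

Compound 4, `COc1cccc(Oc2ccccc2NC(C)=C2C(=O)CC(c3ccccc3)CC2=O)c1`, has not yet been measured. It differs from compound 1 in one place: 3-methoxyphenyl in place of 4-chlorophenyl on an oxygen on an aromatic ring. For the measured compounds named here, the step that bears on it most is the one from compound 1 to compound 3, where a different 3-substituted phenyl took the place of the same 4-chlorophenyl and gave a 4.7-fold lower number from compound 1 to compound 3 (0.67 log units; beyond the scatter). The step to compound 2 shows that changing only the substituent on that ring, a 1.3-fold lower number from compound 1 to compound 2 (0.12 log units; within the scatter), did little. A lowering is therefore expected for compound 4, but a smaller one than for compound 3, since a methoxy group is not an amino group.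

Compound 4 is expected to give 130 nM in this assay, within 55 nM to 310 nM, that is an expected step of a 1.9-fold lower number from compound 1 to compound 4 (0.28 log units; within the scatter).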

Compound 4, half-maximal inhibitory concentration: 58 nM
Estimate against measurement, compound 4: 2.2-fold (0.35 log units) above; the measured number falls inside the stated range.
By their numbers in this assay, from the lowest: compounds 3 and 4 (each within the scatter of the next); then compounds 2 and 1 (each within the scatter of the next).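

In this assay, methoxy in place of amino on the aromatic ring leaves the result unchanged within the scatter, a 1.1-fold higher number from compound 3 to compound 4 (0.04 log units; within the scatter), so the low number of compound 3 does not depend on the amino group alone. The 3-methoxyphenyl group also stands clearly apart from both earlier 4-substituted rings, with a 4.3-fold lower number from compound 1 to compound 4 (0.63 log units; beyond the scatter) and a 3.3-fold lower number from compound 2 to compound 4 (0.52 log units; beyond the scatter). The data given here offer no measurement that explains this shift.

Still open, as far as these compounds go, is whether the number follows the place of the substituent on the ring or the group itself: each step from a 4-substituted to a 3-substituted ring changes both at once. A 4-methoxyphenyl or a 3-chlorophenyl on the same oxygen would separate the two, and a 3-ethoxyphenyl would test a longer chain there.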